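Aryl swap on the benzylidene arm: compound 3 to compound 4

The compounds below may be only part of what the source reports. "The series", "measured", "known", "first", "only" and "open" are said of these compounds alone.

Measured compounds:
compound 1 `C=CCn1c(=O)/c(=C\c2cccc(Cl)c2Cl)[nH]c(=O)/c1=C\c1ccccc1OC` — 2000 nM
compound 2 `C=CCn1c(=O)/c(=C\c2cccc(Br)c2)[nH]c(=O)/c1=C\c1ccccc1OC` — 5200 nM
compound 3 `C=CCn1c(=O)/c(=C\c2ccccc2C(F)(F)F)[nH]c(=O)/c1=C\c1ccccc1OC` — 4600 nM

In a functional assay on HL-60 cells (Homo sapiens) for cytotoxicity, read by CCK-8 assay, with a stated time of 72 h (a higher number here means a weaker inhibitor, a lower number a stronger inhibitor), compound 3 gives 4600 nM, the second highest of the three numbers. The step of a 1.1-fold lower number from compound 2 to compound 3 (0.05 log units; within the scatter) lies within the scatter, so compound 2 and compound 3 cannot be told apart. The step of a 2.3-fold higher number from compound 1 to compound 3 (0.36 log units; beyond the scatter) is modest but beyond the scatter, and compound 1 carries the lowest number of the three.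

Compound 4 is `C=CCn1c(=O)/c(=C\c2ccc(F)c(Br)c2)[nH]c(=O)/c1=C\c1ccccc1OC`. The change is 3-bromo-4-fluorophenyl in place of 2-(trifluoromethyl)phenyl on a double-bonded chain carbon bound to an aromatic carbon. Among the measured compounds shown here, two measured steps bear on it: the swap of one aryl group for another at the same place in a 1.1-fold lower number from compound 2 to compound 3 (0.05 log units; within the scatter) left the number unchanged, and the swap in a 2.6-fold higher number from compound 1 to compound 2 (0.41 log units; beyond the scatter) gave a modest rise. For the measured compounds named here, compound 4 shares the 3-bromo substitution of compound 2, with an added fluorine; no measured step addresses that fluorine. The expected step of a 1.1-fold higher number from compound 3 to compound 4 (0.04 log units; within the scatter) is therefore no change beyond the scatter, with the number of compound 2 as the closest guide. Compound 4 is estimated at 5000 nM in this assay, within a range of 2500 nM to 10000 nM.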

Compound 4, half-maximal inhibitory concentration: "not active" (no number reported)
The entry for compound 4 holds no number, and the estimate cannot be compared.
By their numbers in this assay, from the lowest: compound 1; then compounds 3 and 2 (each within the scatter of the next).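

In this assay, among the compounds shown here, compound 4 is entered as "not active" with no number, so no step from compound 3 or any other compound to compound 4 can be read. No measured property shown accounts for this entry. The compounds shown leave open how the fluorine of the 3-bromo-4-fluorophenyl group alone bears on the result.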